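A few compounds are considered here, and "the series" means these few. Any claim that something is new, unique, unknown or untested is made for them only; others in the source may bear on it.

Compound 1 `Cc1ccc2c(Cc3nn4cc(-c5ccc(Cl)cc5)nc4s3)coc2c1`: 51.7%
Compound 2 `Cc1ccc2c(Cc3nn4cc(-c5ccc([N+](=O)[O-])cc5)nc4s3)coc2c1`: 40.9%
Compound 3 `Cc1ccc2c(Cc3nn4c(C=O)c(-c5ccc(Cl)cc5)nc4s3)coc2c1`: 42.5%

In a functional assay on the whole organism (strain Wistar albino) for inhibition, with Rattus norvegicus as the target, read by paw edema, with a stated time of 3 h, at a dose of 100 mg/kg by the oral route (a higher number here means more inhibition at the dose given (going by the name of the read-out), a lower number less inhibition), compound 1 gives 51.7%, the highest of the three numbers. Compound 3 at 42.5% lies within the scatter of it, whereas compound 2 at 40.9% lies beyond it: a number 10.8 percentage points lower from compound 1 to compound 2 (beyond the scatter).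

Compound 4 `Cc1ccc2c(Cc3nn4c(C#N)c(-c5ccc(Cl)cc5)nc4s3)coc2c1` has not yet been measured. It differs from compound 1 in a single place: cyano in place of hydrogen on an aromatic carbon.

For the measured compounds named here, the step that bears most directly on this change is the one from compound 1 to compound 3, where another small group entered at the same place on the same ring; that gave a number 9.2 percentage points lower from compound 1 to compound 3 (within the scatter). The step from compound 1 to compound 2 altered a different ring and so speaks less to it. A small lowering or no change beyond the scatter is therefore expected for compound 4, a step of a number 6.7 percentage points lower from compound 1 to compound 4 (within the scatter). Compound 4 is estimated to give 45%, within a range of 34% to 56%.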

Compound 4, a percentage reported as inhibition, in the whole organism at one dose (the size of the read-out at that dose, not a potency): 43.4%
The estimate for compound 4 lay 1.6 percentage points above the measured number; the measured number falls inside the stated range.
By their numbers in this assay, from the lowest: compounds 2, 3, 4 and 1 (each within the scatter of the next, the first and the last beyond it).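

In this assay, placing cyano on this aromatic carbon of the five-membered ring gives a number 8.3 percentage points lower from compound 1 to compound 4 (within the scatter), so a second group at this place also leaves the number within the scatter of the unsubstituted compound. Exchanging formyl for cyano at the same carbon gives a number 0.9 percentage points higher from compound 3 to compound 4 (within the scatter), so the two groups cannot be told apart in this read-out. Nothing measured here explains why they read alike.

From the compounds shown here alone, it remains open whether an amine, a carboxylic acid or a longer chain on this carbon would move the number beyond the scatter. Also open, going by these compounds, is whether cyano would give a similar result with a nitro group in place of the chloro on the phenyl ring, and at doses other than the single one tested.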